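Swapping the carbamate alkyl for a methoxyethyl chain

The compounds below may be only part of what the source reports. "The series", "measured", "known", "first", "only" and "open" are said of these compounds alone.

Measured compounds:
compound 1, `CCC(C)OC(=O)NS(=O)(=O)c1sc(CC(C)C)cc1-c1cccc(Cn2ccnc2)c1`, 440 nM
compound 2, `CC(C)Cc1cc(-c2cccc(Cn3ccnc3)c2)c(S(=O)(=O)NC(=O)OC(C)(C)C)s1`, 270 nM

Of the compounds shown here, two have been measured in an assay on HEK293 cells for displacement of a labelled ligand from Type-2 angiotensin II receptor (Homo sapiens), read by scintillation counting, with a stated time of 240 min; a higher number here means a weaker inhibitor, a lower number a stronger inhibitor. Compound 1 gives 440 nM and compound 2 gives 270 nM. Among the compounds with values here, compound 1 has the higher of the two numbers, but the only step between them, a 1.6-fold lower number from compound 1 to compound 2 (0.21 log units; within the scatter), lies within the scatter, so the two values are not distinguished.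

Compound 3 is `COCCOC(=O)NS(=O)(=O)c1sc(CC(C)C)cc1-c1cccc(Cn2ccnc2)c1`. Relative to compound 1 it carries 2-methoxyethyl in place of sec-butyl on an oxygen next to a carbonyl group. Within the data shown here, the one measured step that bears on this position, a 1.6-fold lower number from compound 1 to compound 2 (0.21 log units; within the scatter), shows that exchanging one alkyl group for another on that oxygen did not move the number beyond the scatter. Among the measured compounds shown here, no measured compound carries an oxygen-containing chain at this place, so the effect of the extra acceptor is untested here.

From this, compound 3 is expected to stay close to compound 1, with a step of a 1.1-fold higher number from compound 1 to compound 3 (0.06 log units; within the scatter) that does not exceed the scatter. The estimate for compound 3 in this assay is 500 nM, with a range of 200 nM to 1300 nM.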

Compound 3, inhibition constant: 480 nM
Beside the measured number, compound 3's estimate is 1.0-fold (0.02 log units) above it; measured number inside the range.
By their numbers in this assay, from the lowest: compounds 2, 1 and 3 (each within the scatter of the next).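

In this assay, within the data shown here, the 2-methoxyethyl chain is the first group on this oxygen next to a carbonyl group that holds an oxygen of its own, and putting it in place of sec-butyl gives a 1.1-fold higher number from compound 1 to compound 3 (0.04 log units; within the scatter) while the comparison with tert-butyl gives a 1.8-fold higher number from compound 2 to compound 3 (0.25 log units; within the scatter) and neither step leaves the scatter. The three groups at this place, sec-butyl, tert-butyl and 2-methoxyethyl, are therefore not distinguished from one another in this assay, so a carbon of the chain can be exchanged for an oxygen, at the same count of heavy atoms, without a readable change in the number. No other evidence on this result is available to explain it.

The compounds shown leave open whether this tolerance extends to an amine, a carboxylic acid, a phenyl ring or a longer chain on this oxygen, since all three groups here are small open chains of the same heavy-atom count. Going by these compounds, they also say nothing about the rest of the shared core, which is the same in all three compounds, so whether the number responds to changes elsewhere is unknown.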